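The compounds below may be only part of what the source reports. "The series", "measured", "known", "first", "only" and "open" are said of these compounds alone.

Values measured in a functional assay on HCT-116 cells (Homo sapiens) for antiproliferative activity, with a stated time of 72 h (a lower number here means a stronger inhibitor, a higher number a weaker inhibitor), are these:
compound 1 `Nc1ncnn2c([C@@H]3O[C@H](CO)[C@@H](O)[C@H]3O)cc(C#Cc3ccccc3)c12` gives 46900 nM
compound 2 `Nc1ncnn2c([C@@H]3O[C@H](CO)[C@@H](O)[C@H]3O)cc(-c3ccc(F)cc3F)c12` gives 59500 nM

Set against compound 1, its only neighbour, compound 2 at 59500 nM lies within the scatter. Compound 3 `Nc1ncnn2c([C@@H]3O[C@H](CO)[C@@H](O)[C@H]3O)cc(-c3ccoc3)c12` carries furan-3-yl in place of 2,4-difluorophenyl on an aromatic carbon, and the change is furan-3-yl in place of 2,4-difluorophenyl on an aromatic carbon in full. Going by the values given here, the one measured step at this carbon is a 1.3-fold higher number from compound 1 to compound 2 (0.10 log units; within the scatter) and it stayed within the scatter. Among the compounds with values here, that step involves no five-membered aromatic ring, so it is a thin guide, and no furan-3-yl compound has been measured. In this assay a modest move to a lower number is tentatively expected, and the estimated step is a 2.4-fold lower number from compound 2 to compound 3 (0.38 log units; beyond the scatter) with wide uncertainty. For compound 3 the estimate is 25000 nM with an expected range of 2500 nM to 80000 nM in this test.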

Compound 3, half-maximal inhibitory concentration: 1400 nM
For compound 3 the middle estimate is 18-fold (1.25 log units) above the measured one; measured number below the stated range.
By their numbers in this assay, from the lowest: compound 3; then compounds 1 and 2 (each within the scatter of the next).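

In this assay, the group on this aromatic carbon can shift the number by a large margin: a 43-fold lower number from compound 2 to compound 3 (1.63 log units; beyond the scatter) and a 34-fold lower number from compound 1 to compound 3 (1.53 log units; beyond the scatter) both follow the entry of furan-3-yl. The earlier step between 2-phenylethynyl and 2,4-difluorophenyl stayed within the scatter, so it gave no sign that this carbon could respond so strongly, and only the five-membered aromatic ring with one hetero atom has separated itself from the other two groups. No measurement at hand accounts for this difference.

The compounds shown leave open whether the shift follows the ring oxygen or the five-membered ring itself, a question that thiophen-3-yl or plain phenyl on this carbon would bear on. They also leave open whether furan-2-yl, attached through a different ring carbon, would behave like furan-3-yl.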